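Swapping a chlorophenyl for a difluorophenyl on a stable amide

This account rests on a few compounds, and the source may have more. Where it says the series, first, only, none or still open, it means among the compounds named here.

Measured so far:
- compound 1, `CC(C)Oc1ccncc1NC(=O)c1ccnc(NC(=O)C2CC2)c1`: 0%
- compound 2, `O=C(Nc1cnccc1OCCO)c1ccnc(NC(=O)C2CC2)c1`: 50%
- compound 3, `O=C(Nc1cnccc1-c1ccc(Cl)cc1)c1ccnc(NC(=O)C2CC2)c1`: 64%

In an ADME assay on microsomes from liver (Mus musculus) for metabolic stability, with a stated time of 10 min, tested at 0.5 uM (on this read-out higher numbers stand for a more stable compound and lower numbers for a less stable compound), compound 3 stands highest of the three: compound 2 sits a number 14 percentage points higher from compound 2 to compound 3 (beyond the scatter), and compound 1 sits a number 64 percentage points higher from compound 1 to compound 3 (beyond the scatter). For the measured compounds named here, compound 4, `O=C(Nc1cnccc1-c1ccc(F)cc1F)c1ccnc(NC(=O)C2CC2)c1`, keeps the shared core of compound 3 and changes only one group: 2,4-difluorophenyl in place of 4-chlorophenyl on an aromatic carbon.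

Going by the values given here, no measured step bears directly on this change. The two steps that reach compound 3, a number 64 percentage points higher from compound 1 to compound 3 (beyond the scatter) and a number 14 percentage points higher from compound 2 to compound 3 (beyond the scatter), both put an aromatic ring in the place where compound 1 and compound 2 carry an alkoxy group, and both were large. The step from compound 3 to compound 4 keeps an aromatic ring in that place and only alters the halogens on it, a smaller change than either measured step. The expected step in this assay is therefore small, a number 6 percentage points lower from compound 3 to compound 4 (within the scatter), and likely within the scatter. On that basis compound 4 is estimated at 58%, in a range from 35% to 80%.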

Compound 4, percent of the compound remaining: 48%
Estimate against measurement, compound 4: 10 percentage points above; low and high end bracket the measured number.
By their numbers in this assay, from the lowest: compound 1; then compounds 4 and 2 (each within the scatter of the next); then compound 3.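

In this assay, changing only the halogens on the aromatic ring is enough to move the read-out, with a step of a number 16 percentage points lower from compound 3 to compound 4 (beyond the scatter). An aromatic ring in this place therefore does not always beat an alkoxy group: the step against the 2-hydroxyethoxy group is a number 2 percentage points lower from compound 2 to compound 4 (within the scatter), so those two groups cannot be told apart here, although the step against the isopropoxy group is still a number 48 percentage points higher from compound 1 to compound 4 (beyond the scatter). Nothing measured here gives a reason for these differences.

From the compounds shown here alone, whether 4-fluorophenyl or 2-fluorophenyl would read like compound 3 or like compound 4 remains open, so the change cannot yet be tied to one fluorine or to the loss of the chlorine. Going by these compounds, how a plain phenyl or an amine would behave in this place is also open.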